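Extending the chain when every value is a limit

The source may report more compounds than this note shows. Statements on the series, on what has been measured and on what is new or still open speak of the compounds shown alone.

Values from an ADME assay on cells (Peritoneal macrophage, Mus musculus) for cytotoxicity, read by CCK-8 assay, with a stated time of 24 h; a lower number here means that less compound is tolerated, a higher number that more compound is tolerated (each one a limit):
Compound 1 `COc1ccc(S(=O)(=O)N(CC(N)=O)c2ccc(N(CC(N)=O)S(=O)(=O)c3ccc(S(=O)(=O)CCCCN=C=S)cc3)c3ccccc23)cc1` gives > 10000 nM as a limit
Compound 2 `COc1ccc(S(=O)(=O)N(CC(N)=O)c2ccc(N(CC(N)=O)S(=O)(=O)c3ccc(S(=O)(=O)CCCCCN=C=S)cc3)c3ccccc23)cc1` gives > 10000 nM as a limit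
Compound 3 `COc1ccc(S(=O)(=O)N(CC(N)=O)c2ccc(N(CC(N)=O)S(=O)(=O)c3ccc(S(=O)(=O)CCOCCN=C=S)cc3)c3ccccc23)cc1` gives > 10000 nM as a limit

Within the data shown here, compound 3 therefore stands on a limit and not on a number, with > 10000 nM as its only reading. Across the set the picture is the limit of > 10000 nM in this assay, at which 3 of the 3 values shown sit, and no compound stands apart.

Compound 4 `COc1ccc(S(=O)(=O)N(CC(N)=O)c2ccc(N(CC(N)=O)S(=O)(=O)c3ccc(S(=O)(=O)CCOCCOCCN=C=S)cc3)c3ccccc23)cc1` has not been measured yet. The change from compound 3 to compound 4 is a group of 6 heavy atoms (3 carbon, 1 nitrogen, 1 oxygen, 1 sulfur; no ring) in place of a group of 3 heavy atoms (1 carbon, 1 nitrogen, 1 sulfur; no ring), on a saturated chain carbon, two bonds along the chain from an oxygen on a saturated carbon and it leaves the shared core untouched.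

Among the measured compounds shown here, three measured steps bear on this change: a step that the two limits leave unreadable from compound 1 to compound 3 and a step that the two limits leave unreadable from compound 2 to compound 3 are the nearest, and a step that the two limits leave unreadable from compound 1 to compound 2 is the third. None of them has a readable size, so they offer no measured effect to carry over. The expectation therefore starts from compound 3 with its limit of > 10000 nM as the only anchor. No change beyond the usual scatter is expected in either direction, and the expected move is a step that the limit leaves unreadable from compound 3 to compound 4 in size. Compound 4 will most likely be reported at the same limit. For compound 4 the estimate is 12000 nM with an expected range from 6000 nM to 30000 nM if a number is reported at all.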

Compound 4, half-maximal cytotoxic concentration: > 10000 nM
Compound 4: a limit, no number (the forecaster's own chance of this, stated with the estimate: 85%); the middle value lies beyond the limit too.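

In this assay compound 4 gives > 10000 nM, which is a limit and not a number. Its steps from compound 1, compound 2 and compound 3 cannot be read, and the whole set sits together: the limit of > 10000 nM in this assay, at which 4 of the 4 values shown sit.

The compounds shown leave open at what concentration any of them would harm these cells, and whether their chains differ at all.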